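Chloro on the Far Phenyl: Predicting a Whole-Organism Dose

The source may hold more compounds than are shown below. What is called first, only, known or untested is meant among the compounds shown, and "the series" means these compounds.

Measured so far:
- Compound 1 `COc1ccccc1-n1c(Nc2nc(-c3ccccc3)cs2)n[nH]c1=S`: 100 mg/kg
- Compound 2 `Cc1ccccc1-n1c(Nc2nc(-c3ccccc3)cs2)n[nH]c1=S`: 100 mg/kg

Both compounds were tested in a functional assay on the whole organism (strain Swiss albino) for inhibition, with Mus musculus as the target, with a stated time of 0.5 h; on this read-out lower numbers stand for an effect already at smaller amounts and higher numbers for an effect only at larger amounts of compound. For the measured compounds named here, compound 1 gives 100 mg/kg and compound 2 gives 100 mg/kg, so the two stand level within the scatter; the only measured step, no change at the digits printed from compound 1 to compound 2 (within the scatter), swaps methyl for methoxy on an aromatic carbon and leaves the read-out unchanged.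

Compound 3 `COc1ccccc1-n1c(Nc2nc(-c3ccc(Cl)cc3)cs2)n[nH]c1=S` keeps the methoxy of compound 1 and differs from it elsewhere: chloro in place of hydrogen on an aromatic carbon. Going by the values given here, no measured step touches this phenyl ring, so the one available step bears only indirectly, showing that a small change on a different aromatic ring left this assay unmoved. With nothing pointing either way, no step beyond the scatter is expected in this assay, and the estimated step of no change at the digits printed from compound 1 to compound 3 (within the scatter) reflects that. Compound 3 is therefore expected to give about 100 mg/kg, within 50 mg/kg to 200 mg/kg.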

Compound 3, minimum effective dose: 100 mg/kg
Estimate against measurement, compound 3: no gap at the digits printed, and the stated range covers the measured number.
By their numbers in this assay, from the lowest: compounds 1, 2 and 3 (each within the scatter of the next).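

Going from phenyl to 4-chlorophenyl gives no change at the digits printed from compound 1 to compound 3 (within the scatter) in this assay, and this is the first measured change on this phenyl, since the earlier pair differed only on the ring that carries the methoxy. At this place, para to a large group, the read-out does not separate chloro from hydrogen, so a single chlorine atom here gives no measurable difference in the minimum effective dose. No measurement among the data offers an explanation for this result.

Going by these compounds, whether an amine or a carboxylic acid at the same place would stand apart from compound 1 remains open. Also open, on these data alone, is which single change, if any, on either ring would separate a compound from these three in this assay.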